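Phenylsulfamoyl Replaces a Fluorinated Chain on Compound 1

The source may hold more compounds than are shown below. What is called first, only, known or untested is meant among the compounds shown, and "the series" means these compounds.

Compound 1 `CC#C[C@H]1CN(S(=O)(=O)c2ccc(N)nc2)CCN1c1ccc([C@@](O)(CO)C(F)(F)F)cc1`: 53 mL.min-1.g-1
Compound 2 `CC#C[C@H]1CN(S(=O)(=O)c2ccc(N)nc2)CCN1c1ccc(C(O)(C(F)(F)F)C(F)(F)F)cn1`: 42 mL.min-1.g-1
Compound 3 `CC#C[C@H]1CN(S(=O)(=O)c2ccc(N)nc2)CCN1c1ncc(C(C)(O)C(F)(F)F)s1`: 87 mL.min-1.g-1

All three were tested in an ADME assay (liver) for metabolic stability, with Liver microsome (Rattus norvegicus) as the target, using microsomes and NADPH, with a stated time of 30 min; on this read-out higher numbers stand for fast clearance and lower numbers for slow clearance. Compound 1 sits in the middle of the three numbers, yet its gaps to compound 2 and to compound 3 both fall within the usual scatter, so no order among them can be drawn. Compound 4 `CC#C[C@H]1CN(S(=O)(=O)c2ccc(N)nc2)CCN1c1ccc(S(=O)(=O)Nc2ccccc2)cc1` has not been measured in this assay. It differs from compound 1 by a group of 10 heavy atoms (6 carbon, 1 nitrogen, 2 oxygen, 1 sulfur; one six-membered aromatic ring of carbon only) in place of a group of 8 heavy atoms (3 carbon, 2 oxygen, 3 fluorine; no ring), on an aromatic carbon. Going by the values given here, no measured pair shows this change, so the expectation rests on compound 1 alone. The step from compound 1 to compound 4 is expected to be a 1.5-fold higher number from compound 1 to compound 4 (0.18 log units; within the scatter), a modest move toward faster clearance that may not exceed the scatter. Compound 4 is estimated at 80 mL.min-1.g-1, with a range from 35 mL.min-1.g-1 to 180 mL.min-1.g-1.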

Compound 4, intrinsic clearance in microsomes: > 399 mL.min-1.g-1
Compound 4 gave a limit, no number (the forecaster's own chance of this, stated with the estimate: 5%); at least 4.9-fold (0.69 log units) between middle value and limit.
By their numbers in this assay, from the lowest: compounds 2, 1 and 3 (each within the scatter of the next, the first and the last beyond it). At a limit, above all of these: compound 4.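

Going by these compounds alone, compounds 1 to 3 offered no pair differing in one place, so this is the first single change that can be read at this position, on an aromatic carbon para to a large group. In this assay, phenylsulfamoyl in place of the group of 8 heavy atoms gives an at least 7.5-fold higher number from compound 1 to compound 4 (0.87 log units; beyond the scatter), showing that clearance can depend strongly on what sits here. Compound 4 reached a limit of the assay, not a number: the limit of > 399 mL.min-1.g-1 in this assay, at which 1 of the 4 values shown sits.

Still open, from the compounds shown here alone, is whether the phenyl ring or the sulfonamide link drives this step. Compounds with a methylsulfonamide or a plain primary sulfonamide at this position would help separate the two.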